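Hydrazone series on the shared thiazole-free core: notes on compound 3

A few compounds are considered here, and "the series" means these few. Any claim that something is new, unique, unknown or untested is made for them only; others in the source may bear on it.

Of the compounds shown here, two have numbers so far. Compound 1 `Fc1ccc(/C=N/Nc2nc(-c3ccc(C(F)(F)F)cc3)cs2)cc1F` and compound 2 `Fc1ccc(/C=N/Nc2nc(-c3cc(C(F)(F)F)cc(C(F)(F)F)c3)cs2)cc1F` share the same core and differ only in the aryl group attached to it. In a functional assay on HepG2 cells (Homo sapiens) for inhibition, read by MTT assay, with a stated time of 48 h (a higher number here means a weaker inhibitor, a lower number a stronger inhibitor), compound 1 gives 14500 nM, and in the same assay compound 2 gives 16700 nM. The two values lie within the scatter of each other, so neither compound can be set above the other on this evidence; compound 2 simply sits at the upper end of the pair of numbers.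

Compound 3 `COc1cc(/C=N/Nc2nc(-c3cc(C(F)(F)F)cc(C(F)(F)F)c3)cs2)cc(Br)c1OC` is the next member and has not yet been measured. It differs from compound 2 in one place: 3-bromo-4,5-dimethoxyphenyl in place of 3,4-difluorophenyl on a carbon with a double bond to nitrogen. Among the compounds with values here, no measured pair changes the group on that carbon, so there is no precedent for the size or direction of the step. The expectation is therefore a step of a 1.2-fold lower number from compound 2 to compound 3 (0.08 log units; within the scatter), none beyond the scatter. Compound 3 is expected to give 14000 nM in this assay, within a range of 4500 nM to 45000 nM.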

Compound 3, half-maximal inhibitory concentration: > 100000 nM
Compound 3: only a limit was reported; the forecaster's own chance of this, stated with the estimate: 15%; middle value at least 7.1-fold (0.85 log units) away from the limit.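

In this assay, the carbon with a double bond to nitrogen proves to be a place where a change in the group moves the number: 3-bromo-4,5-dimethoxyphenyl in place of 3,4-difluorophenyl gives an at least 5.9-fold higher number from compound 2 to compound 3 (0.77 log units; beyond the scatter). For compound 3 only a limit is reported, and the step is therefore a lower bound, with its true size unknown: the limit of > 100000 nM in this assay, at which 1 of the 3 values shown sits. Within the data shown here, compound 1 and compound 2 differ in another place and lie within the scatter of each other, so this is the first step to pass beyond the scatter, though a single pair sets no trend for this position.

The 3-bromo-4,5-dimethoxyphenyl group enters as a whole, so the compounds shown do not separate the part played by the bromine from that played by the methoxy groups, and they do not show whether the step would recur on the core of compound 1. Also open, on these data alone, is whether an unsubstituted phenyl, or a phenyl carrying an amine or a carboxylic acid, in that place would stay close to compound 2 at 16700 nM.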